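A few compounds are considered here, and "the series" means these few. Any claim that something is new, unique, unknown or untested is made for them only; others in the source may bear on it.

In a functional assay on L1210 cells (Mus musculus) for inhibition (a higher number here means a weaker inhibitor, a lower number a stronger inhibitor), compound 3 `Nc1ncnc2c1c(Cl)cn2COC(CO)CO` gives 2300 nM, the lowest of the two numbers shown. Compound 1 `OCC(CO)OCn1cc(I)c2c(NO)ncnc21` gives 39000 nM in this assay. For compound 2 `CCNc1ncnc2c1c(Cl)cn2COC(CO)CO` only a limit is reported, > 100000 nM, which is the limit of > 100000 nM in this assay, at which 1 of the 3 values shown sits. Among the measured compounds shown here, the single measured step, an at least 43-fold lower number from compound 2 to compound 3 (1.63 log units; beyond the scatter), concerns a substituent on the same nitrogen. Compound 4 `OCC(CO)OCn1cc(Cl)c2c(NO)ncnc21` differs from compound 3 by hydroxy in place of hydrogen on a nitrogen on an aromatic ring. For the measured compounds named here, no measured step covers exactly this change; compound 1, which also carries the hydroxyamino group, stands far higher than compound 3. A rise is therefore expected for compound 4 in this assay, of about an 8.7-fold higher number from compound 3 to compound 4 (0.94 log units; beyond the scatter), to an estimated 20000 nM with a range from 5000 nM to 80000 nM.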

Compound 4, half-maximal inhibitory concentration: 75000 nM
Beside the measured number, compound 4's estimate is 3.8-fold (0.57 log units) below it, within the range that was stated.
By their numbers in this assay, from the lowest: compound 3; then compounds 1 and 4 (each within the scatter of the next). At a limit, above all of these: compound 2.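

In this assay, hydroxy in place of hydrogen on this nitrogen gives a 33-fold higher number from compound 3 to compound 4 (1.51 log units; beyond the scatter), so the free amino group is now set against a second substituent there, and that substituent also gives a large rise. With ethyl, the other substituent on this nitrogen, the comparison reads an at least 1.3-fold lower number from compound 2 to compound 4 (0.12 log units; that floor lies within the scatter), which fixes no order, and compound 2 stands at a limit: the limit of > 100000 nM in this assay, at which 1 of the 4 values shown sits. With the hydroxyamino group in place, chloro in place of iodo gives a 1.9-fold higher number from compound 1 to compound 4 (0.28 log units; within the scatter), so the two halogens are not told apart.

Open, on these data alone, is what a methyl group or a methoxy group on this nitrogen would give. Also open, as far as these compounds go, is whether iodo and chloro would stay as close with the plain amino group.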